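One Added Methyl on the Chain of Compound 3

A few compounds are considered here, and "the series" means these few. Any claim that something is new, unique, unknown or untested is made for them only; others in the source may bear on it.

Measured in a functional assay on A549 cells (Homo sapiens) for inhibition, read by MTT assay, with a stated time of 72 h; on this read-out higher numbers stand for weaker inhibition and lower numbers for stronger inhibition:

- Compound 1 `COc1cc(N(C)CCN(C)C)c(NC(=O)/C=C\C(C)C)cc1Nc1nc2c(c(-c3cn(C)c4ccc(F)cc34)n1)CSCC2` gives 1150 nM
- Compound 2 `C=CC(=O)Nc1cc(Nc2nc3c(c(-c4cn(C)c5ccccc45)n2)CSCC3)c(OC)cc1N(C)CCN(C)C` gives 506 nM
- Compound 3 `CC/C=C\C(=O)Nc1cc(Nc2nc3c(c(-c4cn(C)c5ccccc45)n2)CSCC3)c(OC)cc1N(C)CCN(C)C` gives 236 nM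

Of these three, compound 3 has the lowest number, meaning the strongest inhibition. Compound 4 `COc1cc(N(C)CCN(C)C)c(NC(=O)/C=C\C(C)C)cc1Nc1nc2c(c(-c3cn(C)c4ccccc34)n1)CSCC2` differs from it by one change: methyl in place of hydrogen on a saturated chain carbon bound to a double-bonded chain carbon and a saturated chain carbon. In other words, ethyl becomes isopropyl. Going by the values given here, the only measured step on this chain, a 2.1-fold lower number from compound 2 to compound 3 (0.33 log units; beyond the scatter), is modest and swaps vinyl for but-1-en-1-yl. It is a different change, so it offers only a rough guide to size. Compound 1 carries the same (3-methylbut-1-en-1-yl)carbonyl group as compound 4 but differs elsewhere, and compound 1 gives 1150 nM. A modest rise in this assay is therefore expected, with the estimated step being a 1.8-fold higher number from compound 3 to compound 4 (0.25 log units; within the scatter). For compound 4 the estimate is 420 nM, with an expected range from 170 nM to 1000 nM.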

Compound 4, half-maximal inhibitory concentration: 788 nM
Compound 4: middle estimate off by 1.9-fold (0.27 log units), on the low side, within the range that was stated.
By their numbers in this assay, from the lowest: compound 3; then compounds 2, 4 and 1 (each within the scatter of the next, the first and the last beyond it).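

In this assay, this single methyl on the saturated chain carbon turns out to matter, as ethyl to isopropyl gives a 3.3-fold higher number from compound 3 to compound 4 (0.52 log units; beyond the scatter) and separates the two compounds clearly. The branched group leaves compound 4 within the scatter of the vinyl compound (a 1.6-fold higher number from compound 2 to compound 4 (0.19 log units; within the scatter)), and hydrogen in place of fluoro also stays within it (a 1.5-fold lower number from compound 1 to compound 4 (0.16 log units; within the scatter)). No measurement here explains the effect of the methyl.

Still open, as far as these compounds go, is how a longer straight chain or an amine at this carbon would read. Also open, from the compounds shown here alone, is whether the methyl step holds when the core carries fluoro.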